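A carbonyl leaves the side chain of compound 3

The source may hold more compounds than are shown below. What is called first, only, known or untested is meant among the compounds shown, and "the series" means these compounds.

Measured in a functional assay on HEL cells (Homo sapiens); a lower number here means that less compound is tolerated, a higher number that more compound is tolerated:
Compound 1 `CCOC(=O)NC(=O)NC1=CS(=O)(=O)O[C@@]12[C@@H](CO[Si](C)(C)C(C)(C)C)O[C@@H](n1cc(C)c(=O)n(C)c1=O)[C@@H]2O[Si](C)(C)C(C)(C)C` gives 14000 nM
Compound 2 `CC(=O)NC1=CS(=O)(=O)O[C@@]12[C@@H](CO[Si](C)(C)C(C)(C)C)O[C@@H](n1cc(C)c(=O)n(C)c1=O)[C@@H]2O[Si](C)(C)C(C)(C)C` gives > 200000 nM (a limit of the assay)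
Compound 3 `Cc1cn([C@@H]2O[C@H](CO[Si](C)(C)C(C)(C)C)[C@@]3(OS(=O)(=O)C=C3NCC(=O)C(N)=O)[C@H]2O[Si](C)(C)C(C)(C)C)c(=O)n(C)c1=O` gives 14500 nM

Compound 3 stands level with compound 1, with a 1.0-fold higher number from compound 1 to compound 3 (0.02 log units; within the scatter) on record. The entry for compound 2 is a limit.

Compound 4 `Cc1cn([C@@H]2O[C@H](CO[Si](C)(C)C(C)(C)C)[C@@]3(OS(=O)(=O)C=C3NCCC(N)=O)[C@H]2O[Si](C)(C)C(C)(C)C)c(=O)n(C)c1=O` differs from compound 3 in one place: carbamoylmethyl in place of carbamoylcarbonyl on a saturated chain carbon bound to an amine nitrogen. Within the data shown here, no measured step makes this exact change, but three alter the group on the same amine nitrogen. Both large ones involve compound 2, namely an at least 14-fold higher number from compound 1 to compound 2 (1.15 log units; beyond the scatter) and an at least 13-fold lower number from compound 2 to compound 3 (1.13 log units; beyond the scatter). The new 2-carbamoylethyl chain stays closer to the (carbamoylcarbonyl)methyl of compound 3, at 14500 nM, than to the acetyl of compound 2. A small step to a higher number in this assay is therefore expected, estimated as a 1.5-fold higher number from compound 3 to compound 4 (0.18 log units; within the scatter). For compound 4 the estimate is 22000 nM, with an expected range from 9000 nM to 90000 nM.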

Compound 4, half-maximal cytotoxic concentration: 14800 nM
Estimate against measurement, compound 4: 1.5-fold (0.17 log units) above; measured number inside the range.
By their numbers in this assay, from the lowest: compounds 1, 3 and 4 (each within the scatter of the next). At a limit, above all of these: compound 2.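

In this assay, exchanging carbamoylcarbonyl for carbamoylmethyl on a saturated chain carbon bound to an amine nitrogen gives a 1.0-fold higher number from compound 3 to compound 4 (0.01 log units; within the scatter), so the loss of this carbonyl from the side chain makes no difference that this assay can resolve. The 2-carbamoylethyl chain also stands level with the (ethoxycarbonyl)carbamoyl group, with a 1.1-fold higher number from compound 1 to compound 4 (0.02 log units; within the scatter), so three different groups on this amine nitrogen now share one level. Only the acetyl group stands apart, with an at least 13-fold lower number from compound 2 to compound 4 (1.13 log units; beyond the scatter), a step that rests on a limit of the assay: the limit of > 200000 nM in this assay, at which 1 of the 4 values shown sits.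

The compounds shown leave open whether the number holds when a carboxylic acid or an amine replaces the carbamoyl of the 2-carbamoylethyl chain, or when a longer chain carries it. They also leave open whether a propionyl group on the amine nitrogen would stay with the acetyl group at the limit or join the other three.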